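A phenyl swap from compound 3 to compound 4

The compounds below may be only part of what the source reports. "The series", "measured", "known", "first", "only" and "open" are said of these compounds alone.

Compound 1 `N#Cc1ccc(-c2nc(NCCNc3ccc([N+](=O)[O-])c(N)n3)ncc2-c2ncc[nH]2)cc1`: > 0.5 h
Compound 2 `Nc1nc(NCCNc2ncc(-c3ncc[nH]3)c(-c3cc(F)ccc3F)n2)ccc1[N+](=O)[O-]`: > 0.5 h
Compound 3 `Nc1nc(NCCNc2ncc(-c3ncc[nH]3)c(-c3cc(F)c(Cl)cc3F)n2)ccc1[N+](=O)[O-]`: > 0.5 h

In an ADME assay on microsomes from liver (Canis lupus familiaris) for metabolic stability (on this read-out higher numbers stand for a longer-lived compound and lower numbers for a shorter-lived compound), compound 3 gives > 0.5 h, which is a limit and not a number. It shares its place with the other two compounds, at the limit of > 0.5 h in this assay, at which 3 of the 3 values shown sit.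

Compound 4 `Cc1ccc(-c2nc(NCCNc3ccc([N+](=O)[O-])c(N)n3)ncc2-c2ncc[nH]2)c(Br)c1` carries 2-bromo-4-methylphenyl in place of 4-chloro-2,5-difluorophenyl on an aromatic carbon.

Within the data shown here, three measured steps bear on this change. There is a step that the two limits leave unreadable from compound 1 to compound 2, there is a step that the two limits leave unreadable from compound 1 to compound 3, and there is a step that the two limits leave unreadable from compound 2 to compound 3. None of them gives a size or a direction, so no step beyond the usual scatter is expected in this assay.

The expected step is a step that the limit leaves unreadable from compound 3 to compound 4, and this remains an estimate resting on limits alone. For compound 4 the estimated value is 0.7 h, with an expected range from 0.35 h to 1.5 h.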

Compound 4, half-life: > 0.5 h
Compound 4: no number, only a limit; the forecaster's own chance of this, stated with the estimate: 75%; the middle value does not contradict the limit.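

In this assay compound 4 gives > 0.5 h, which is a limit and not a number. Its steps from compound 1, compound 2 and compound 3 therefore cannot be read, and all four compounds share one place: the limit of > 0.5 h in this assay, at which 4 of the 4 values shown sit.

The compounds shown leave open what the half-life of any of them is, and whether swapping the phenyl groups changes it at all.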